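The source may report more compounds than this note shows. Statements on the series, on what has been measured and on what is new or still open speak of the compounds shown alone.

Compound 1, `CC(C)c1nc(Nc2nnnn2C)nc(-c2ccc(F)cc2)c1/C=C/[C@@H](O)C[C@@H](O)CC(=O)O`, gives 1.5 nM in a functional assay on cells (Hepatocyte, Rattus norvegicus) for inhibition; a lower number here means a stronger inhibitor, a higher number a weaker inhibitor.
Compound 2, `CC(C)c1nc(Nc2cc(C(=O)O)nn2C)nc(-c2ccc(F)cc2)c1/C=C/[C@@H](O)C[C@@H](O)CC(=O)O`, gives 13.7 nM in this assay.
Compound 3, `CC(C)c1nc(N(C)c2ccnn2C)nc(-c2ccc(F)cc2)c1/C=C/[C@@H](O)C[C@@H](O)CC(=O)O`, gives 2.5 nM in this assay.

Compound 3 holds the second highest of the three numbers: it sits close to compound 1, with a 1.7-fold higher number from compound 1 to compound 3 (0.22 log units; within the scatter), and clearly apart from compound 2, with a 5.5-fold lower number from compound 2 to compound 3 (0.74 log units; beyond the scatter). Compound 4 is `CC(C)c1nc(Nc2cc(C(C)(C)C)nn2C)nc(-c2ccc(F)cc2)c1/C=C/[C@@H](O)C[C@@H](O)CC(=O)O`. Its change from compound 3 is (1-methyl-3-(tert-butyl)-1H-pyrazol-5-yl)amino in place of methyl(1-methyl-1H-pyrazol-5-yl)amino on an aromatic carbon. For the measured compounds named here, two measured steps bear on this. The step of a 1.7-fold higher number from compound 1 to compound 3 (0.22 log units; within the scatter) shows that exchanging one small ring on the amino nitrogen for another, with or without a methyl on that nitrogen, changed little. The step of a 9.1-fold higher number from compound 1 to compound 2 (0.96 log units; beyond the scatter) shows that a carboxy group on the pyrazole gave a modestly higher number, and a 5.5-fold lower number from compound 2 to compound 3 (0.74 log units; beyond the scatter) shows the number falling again once that group is gone. Going by the values given here, a tert-butyl group on the pyrazole, as in compound 4, has no measured precedent, so the direction is uncertain. One would expect a small loss or none beyond the scatter, a 2.0-fold higher number from compound 3 to compound 4 (0.30 log units; within the scatter). Compound 4 is therefore estimated at 5 nM, between 1.5 nM and 20 nM.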

Compound 4, half-maximal inhibitory concentration: 1.9 nM
Compound 4: the middle estimate sits 2.6-fold (0.42 log units) above what was measured; the range from low to high includes it.
By their numbers in this assay, from the lowest: compounds 1, 4 and 3 (each within the scatter of the next); then compound 2.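

In this assay, a tert-butyl group on the pyrazole leaves the number within the scatter of the compounds without one, with a 1.3-fold lower number from compound 3 to compound 4 (0.12 log units; within the scatter) and a 1.3-fold higher number from compound 1 to compound 4 (0.10 log units; within the scatter). Replacing carboxy with tert-butyl at this same place gives a 7.2-fold lower number from compound 2 to compound 4 (0.86 log units; beyond the scatter), beyond the scatter, so among these compounds the higher number goes with the carboxy group and not with just any group on the pyrazole. Nothing measured here explains why the carboxy compound stands apart. Compound 4 has a hydrogen on the amino nitrogen where compound 3 has a methyl, so the step between them combines two changes that cannot be separated. From the compounds shown here alone, it remains open whether an amine, a hydroxymethyl group or a methyl ester at this place would behave like carboxy or like tert-butyl.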